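Benzyl for cyclohexyl on the ring nitrogen: compound 4

A few compounds are considered here, and "the series" means these few. Any claim that something is new, unique, unknown or untested is made for them only; others in the source may bear on it.

Three measured compounds share a core that carries a cyclohexyl on an aromatic nitrogen of a five-membered aromatic ring. In a functional assay on OVCAR-5 cells (Homo sapiens) for inhibition, read by sulforhodamine B assay, with a stated time of 48 h, tested at 10 uM (a lower number here means less inhibition, a higher number more inhibition at the concentration tested (going by the name of the read-out)), compound 1 `Brc1cn2ccnc2c(-c2ccc3ncn(C4CCCCC4)c3c2)n1` gives 6.64%, and compound 2 `c1ccc(-c2cn3ccnc3c(-c3ccc4ncn(C5CCCCC5)c4c3)n2)cc1` gives 7.87%; the step of a number 1.2 percentage points higher from compound 1 to compound 2 (within the scatter) concerns a substituent on an aromatic carbon. Compound 3 `c1cn2cc(-c3ccc4c(c3)ncn4C3CCCCC3)nc(-c3ccc4ncn(C5CCCCC5)c4c3)c2n1` gives 1.44%, the lowest of the three numbers as they stand, though its gaps to compound 1 and to compound 2 both lie within the scatter, so the three cannot be ranked.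

Compound 4 `c1ccc(Cn2cnc3ccc(-c4nc(-c5ccc6c(c5)ncn6C5CCCCC5)cn5ccnc45)cc32)cc1` differs from compound 3 in one place: benzyl in place of cyclohexyl on an aromatic nitrogen. For the measured compounds named here, no measured step touches the group on the aromatic nitrogen; the only step in hand sits on an aromatic carbon and stayed within the scatter. All three numbers lie low on the scale, and nothing in the series points to movement beyond the scatter for a change at this position. A step of a number 1.6 percentage points higher from compound 3 to compound 4 (within the scatter) that stays within the scatter is therefore expected. Compound 4 is expected to give about 3%, in a range from -6% to 13%.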

Compound 4, a percentage reported as inhibition, at one concentration (the size of the read-out at that concentration, not a potency): -29%
Compound 4: middle estimate off by 32 percentage points, on the high side; measured number below the stated range.
By their numbers in this assay, from the lowest: compound 4; then compounds 3, 1 and 2 (each within the scatter of the next).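

Benzyl in place of cyclohexyl on an aromatic nitrogen of a five-membered aromatic ring gives the first step in the series to pass the scatter in this assay: a number 30.4 percentage points lower from compound 3 to compound 4 (beyond the scatter) in a compound that keeps its other cyclohexyl unchanged. The only earlier step, a number 1.2 percentage points higher from compound 1 to compound 2 (within the scatter) on an aromatic carbon, gave no sign of this, so the group on the ring nitrogen is now the one place shown where a single change moves the number, and compound 4 at -29% takes the read-out below zero, whereas compounds 1, 2 and 3 all stay above it. Nothing at hand explains the drop or says what a negative number means in this read-out.

Going by these compounds, it remains open whether benzyl would act the same way on the other ring nitrogen, or on the single-substituent scaffold of compound 1 or compound 2, since this rests on one pair. On these data alone, it is also open whether the step follows the aromatic ring or the carbon link of benzyl, which phenyl or phenethyl on the same nitrogen could separate, and how a methyl or an aminoethyl chain would read there.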